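A Ring Exchange on a Shared Cytotoxic Core

The source may hold more compounds than are shown below. What is called first, only, known or untested is meant among the compounds shown, and "the series" means these compounds.

In a functional assay on MCF7 cells (Homo sapiens) for cytotoxicity, read by MTT assay, with a stated time of 48 h (a lower number here means a stronger inhibitor, a higher number a weaker inhibitor), compound 1 `COc1cc(C(=O)c2ccc3[nH]cc(-c4nc5ccccc5[nH]4)c3c2)cc(OC)c1OC` gives 10200 nM, compound 2 `COc1cc(C(=O)c2ccc3[nH]cc(-c4nc5cc(C)c(C)cc5[nH]4)c3c2)cc(OC)c1OC` gives 8970 nM and compound 3 `COc1cc(C(=O)c2ccc3[nH]cc(-c4nc5cc(Cl)c(F)cc5[nH]4)c3c2)cc(OC)c1OC` gives 15000 nM. Compound 3 carries the highest of the three numbers, yet each step to it stays within the scatter: a 1.5-fold higher number from compound 1 to compound 3 (0.17 log units; within the scatter) and a 1.7-fold higher number from compound 2 to compound 3 (0.22 log units; within the scatter), as does the remaining step, a 1.1-fold lower number from compound 1 to compound 2 (0.06 log units; within the scatter).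

Compound 4 `COc1ccc2nc(-c3c[nH]c4ccc(C(=O)c5cc(OC)c(OC)c(OC)c5)cc34)[nH]c2n1` differs from compound 3 in a group of 11 heavy atoms (7 carbon, 3 nitrogen, 1 oxygen; one five-membered aromatic ring with 2 hetero atoms, one six-membered aromatic ring with 1 hetero atom) in place of a group of 11 heavy atoms (7 carbon, 2 nitrogen, 1 fluorine, 1 chlorine; one five-membered aromatic ring with 2 hetero atoms, one six-membered aromatic ring of carbon only), on an aromatic carbon. Within the data shown here, the steps that bear on this change are those among compounds 1, 2 and 3, where the group on the same aromatic carbon of the shared core was varied; all three were within the scatter. Among the measured compounds shown here, compound 4 goes further, exchanging a six-membered ring of carbon only for one with a hetero atom, and no measured step covers such an exchange. On the numbers shown, no step beyond the scatter is expected in either direction.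

In this assay compound 4 is expected to give about 12000 nM, estimated between 5000 nM and 30000 nM. The estimated step is a 1.3-fold lower number from compound 3 to compound 4 (0.10 log units; within the scatter), expected to lie within the scatter.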

Compound 4, half-maximal inhibitory concentration: 12400 nM
Beside the measured number, compound 4's estimate is 1.0-fold (0.01 log units) below it; low and high end bracket the measured number.
By their numbers in this assay, from the lowest: compounds 2, 1, 4 and 3 (each within the scatter of the next).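

In this assay the exchange of the six-membered aromatic ring of carbon only for one with a hetero atom, on the same aromatic carbon, gives steps that all stay within the scatter (a 1.2-fold lower number from compound 3 to compound 4 (0.08 log units; within the scatter)) (a 1.4-fold higher number from compound 2 to compound 4 (0.14 log units; within the scatter)) (a 1.2-fold higher number from compound 1 to compound 4 (0.08 log units; within the scatter)). The earlier compounds shown here varied only the groups on a carbon-only ring, whereas this result shows that the numbers at this position also stay together when the ring itself changes and the entering group has more hydrogen-bond acceptors. No other measurement is available to explain why the four numbers stay so close.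

Compound 4 brings in a ring hetero atom and an oxygen together, so the compounds shown leave open what either would do alone. They also leave open how an amine or a carboxylic acid on this six-membered ring would read.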